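Carboxymethyl on the saturated ring of compound 2

A few compounds are considered here, and "the series" means these few. Any claim that something is new, unique, unknown or untested is made for them only; others in the source may bear on it.

Measured in an ADME assay on microsomes from liver (Mus musculus) for metabolic stability, read by LC-MS, using NADPH, with a stated time of 60 min, tested at 1 uM; on this read-out higher numbers stand for fast clearance and lower numbers for slow clearance:
compound 1 `O=S(=O)(c1cccc(C(F)(F)F)c1)N1CCc2ccc(OCc3c(F)cccc3Cl)cc21`: 482 mL.min-1.g-1
compound 2 `O=S(=O)(c1cccc(C(F)(F)F)c1)N1CCc2ccc(-c3cc(F)cc(OC(F)F)c3)cc21`: 121 mL.min-1.g-1

Compound 2 has the lower of the two numbers. Within the data shown here, the only measured step is a 4.0-fold lower number from compound 1 to compound 2 (0.60 log units; beyond the scatter), with 3-(difluoromethoxy)-5-fluorophenyl in place of (2-chloro-6-fluorobenzyl)oxy on an aromatic carbon.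

Compound 3 `O=C(O)CC1Cc2ccc(-c3cc(F)cc(OC(F)F)c3)cc2N1S(=O)(=O)c1cccc(C(F)(F)F)c1` differs from compound 2 by carboxymethyl in place of hydrogen on a saturated ring carbon. The measured step lies at another place, so it offers a rough size for a single change but no direction for this one. Among the measured compounds shown here, no measured compound carries a group on this ring carbon, and the expectation is therefore tentative. A modest drop in this assay is expected, with no change beyond the scatter still possible. The expected step is a 2.7-fold lower number from compound 2 to compound 3 (0.43 log units; beyond the scatter). For compound 3 the estimate is 45 mL.min-1.g-1, with an expected range of 15 mL.min-1.g-1 to 130 mL.min-1.g-1.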

Compound 3, intrinsic clearance in microsomes in the Mus musculus assay: 12.3 mL.min-1.g-1
For compound 3 the middle estimate is 3.7-fold (0.56 log units) above the measured one, and the stated range ends above it.
By their numbers in the Mus musculus assay, from the lowest: compound 3; then compound 2; then compound 1.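

In the Mus musculus assay the saturated ring carbon next to the ring nitrogen, which bears only hydrogen in compound 1 and compound 2, responds strongly to substitution: carboxymethyl in place of hydrogen gives a 9.8-fold lower number from compound 2 to compound 3 (0.99 log units; beyond the scatter). Among these compounds, this gives a direction for this position, where the earlier compounds offered only a change on an aromatic carbon. In a physicochemical assay for solubility, read by LC-MS, in phosphate buffer, measured as kinetic solubility, with a stated time of 120 min, at pH 7.46, tested at 100 uM (a higher number here means a more soluble compound, a lower number a less soluble compound), compound 2 gives 1480 nM and compound 3 gives 69400 nM. In the physicochemical assay the same single change also goes with higher solubility, so one substitution here moves both read-outs in the favourable direction: the measured solubility of compound 2, 1480 nM, and of compound 3, 69400 nM, a 47-fold higher number (1.67 log units; beyond the scatter)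

Open, going by these compounds, is whether both steps belong to carboxymethyl itself or would also appear with a methyl ester, a primary amide or a longer chain ending in a carboxylic acid on this ring carbon. Also open, on these data alone, is whether they would hold with the (2-chloro-6-fluorobenzyl)oxy group of compound 1 in place of 3-(difluoromethoxy)-5-fluorophenyl.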